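Trimming the Linker: From Compound 2 to Compound 4

The compounds below may be only part of what the source reports. "The series", "measured", "known", "first", "only" and "open" are said of these compounds alone.

Of the compounds shown here, three sharing one core have been tested in a functional assay on CCRF-CEM cells (Homo sapiens) for inhibition, read by MTT assay, with a stated time of 72 h; on this read-out higher numbers stand for weaker inhibition and lower numbers for stronger inhibition. Compound 1 `COc1cc(NC(C)CCCNC(=O)NNC(=O)Nc2cccc(C(F)(F)F)c2)c2ncccc2c1` gives 6900 nM, compound 3 `COc1cc(NC(C)CCCNC(=O)NNC(=O)Nc2ccc(C(F)(F)F)cc2)c2ncccc2c1` gives 18000 nM, and compound 2 `COc1cc(NC(C)CCCNC(=O)NNC(=O)Nc2cccc(Cl)c2)c2ncccc2c1` gives 81000 nM, the highest number of the three. Compound 4 `COc1cc(NC(C)CCCNC(=O)Nc2ccc(Cl)cc2)c2ncccc2c1` is not yet measured; the change from compound 2 is 4-chlorophenyl in place of ((3-chlorophenyl)carbamoyl)amino on an amide-type nitrogen. The known steps only swap one aromatic group for another: a 12-fold higher number from compound 1 to compound 2 (1.07 log units; beyond the scatter), a 2.6-fold higher number from compound 1 to compound 3 (0.42 log units; beyond the scatter) and a 4.5-fold lower number from compound 2 to compound 3 (0.65 log units; beyond the scatter). Going by the values given here, none of them shortens the chain, so no measured step bears directly on this change, and the direction of the coming step is open. Compound 4 is expected near 40000 nM, within 5000 nM to 200000 nM. The expected step is a 2.0-fold lower number from compound 2 to compound 4 (0.31 log units; beyond the scatter), with wide uncertainty.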

Compound 4, half-maximal inhibitory concentration: 24000 nM
The estimate for compound 4 lay 1.7-fold (0.22 log units) above the measured number, and the stated range covers the measured number.
By their numbers in this assay, from the lowest: compound 1; then compounds 3 and 4 (each within the scatter of the next); then compound 2.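

Earlier steps only swapped one aromatic group for another, whereas this change removes part of the group on the amide-type nitrogen, including its hydrogen-bond donors and acceptor. In this assay, replacing ((3-chlorophenyl)carbamoyl)amino with 4-chlorophenyl gives a 3.4-fold lower number from compound 2 to compound 4 (0.53 log units; beyond the scatter), so inhibition improves rather than being lost. Nothing available explains this gain.

The step also changes 3-chlorophenyl to 4-chlorophenyl, so the contributions of the shortening and the chlorine's new place cannot be separated. On these data alone, how an amine or a carboxylic acid on that phenyl ring would read out remains open.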